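Trifluoromethyl on the distal ring of compound 3

A few compounds are considered here, and "the series" means these few. Any claim that something is new, unique, unknown or untested is made for them only; others in the source may bear on it.

Measured compounds:
compound 1, `O=C(CCc1cccc2c1B(O)OC2)NCc1ccccc1`, > 100000 nM
compound 2, `O=C(CCc1cccc2c1B(O)OC2)Nc1ccccc1-c1ccccc1`, 26000 nM
compound 3, `O=C(CCc1cccc2c1B(O)OC2)Nc1cccc(-c2ccccc2)c1`, 250 nM

Three amides share one boron-containing core and differ in the group on the amide nitrogen. In a functional assay on SK-OV-3 cells (Homo sapiens) for antiproliferative activity, read by MTT assay, with a stated time of 72 h (on this read-out higher numbers stand for weaker inhibition and lower numbers for stronger inhibition), compound 1 reaches only a limit, > 100000 nM, so no number is known for it; that limit is the limit of > 100000 nM in this assay, at which 1 of the 3 values shown sits. Compound 2, carrying the second phenyl ring at one position of the anilide, gives 26000 nM in this assay. Compound 3, with the second phenyl ring moved to another position, gives 250 nM, the lowest number among the measured compounds, with compound 2 far beyond the scatter above it.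

Compound 4, `O=C(CCc1cccc2c1B(O)OC2)Nc1cccc(-c2cccc(C(F)(F)F)c2)c1`, differs from compound 3 by trifluoromethyl in place of hydrogen on an aromatic carbon, that is, phenyl becomes 3-(trifluoromethyl)phenyl. For the measured compounds named here, no measured pair shows a change of this kind, so the step is expected to be small, with a slight lean toward a lower number: the expected step from compound 3 to compound 4 is a 1.4-fold lower number from compound 3 to compound 4 (0.14 log units; within the scatter). Compound 4 is therefore estimated at 180 nM, within a range from 50 nM to 700 nM.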

Compound 4, half-maximal inhibitory concentration: 390 nM
Beside the measured number, compound 4's estimate is 2.2-fold (0.34 log units) below it; measured number inside the range.
By their numbers in this assay, from the lowest: compounds 3 and 4 (each within the scatter of the next); then compound 2. At a limit, above all of these: compound 1.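

In this assay, trifluoromethyl in place of hydrogen on the outer phenyl ring gives a 1.6-fold higher number from compound 3 to compound 4 (0.19 log units; within the scatter), so this change leaves compound 4 indistinguishable from compound 3. The earlier compounds shown here varied only the group on the amide nitrogen and where the second phenyl ring is attached, whereas this pair shows that a carbon of the outer ring, meta to a large group, can carry a substituent of this size with no step beyond the scatter. Nothing given here bears on why the read-out stays within the scatter for this change.

On these data alone, this is a single substituent at a single place, so it remains open whether an amine, a carboxylic acid or a methoxy group would behave the same way there. As far as these compounds go, it is equally open whether trifluoromethyl would be accommodated on the other carbons of that ring.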